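From Acetyl to Propargyl on a Shared Core

The source may hold more compounds than are shown below. What is called first, only, known or untested is meant among the compounds shown, and "the series" means these compounds.

In a functional assay on HL-60 cells (Homo sapiens) for cytotoxicity, read by MTT assay, with a stated time of 24 h (a higher number here means a weaker inhibitor, a lower number a stronger inhibitor), compound 1 `Brc1ccc(Oc2cc(Br)cc(Br)c2OCCCCCN2CCN(c3ccccc3)CC2)c(Br)c1` gives 41.6 ug/mL and compound 3 `CC(C)(C)OC(=O)N1CCN(CCCCCOc2c(Br)cc(Br)cc2Oc2ccc(Br)cc2Br)CC1` gives 32.1 ug/mL while compound 2 `CC(=O)Oc1c(Br)cc(Br)cc1Oc1ccc(Br)cc1Br` gives 29.9 ug/mL on the same scale. These three numbers lie within the scatter of one another, so compound 2 cannot be ranked against the other two. Compound 4 `C#CCOc1c(Br)cc(Br)cc1Oc1ccc(Br)cc1Br` differs from compound 2 by propargyl in place of acetyl on an oxygen on an aromatic ring which in words is propargyl in place of acetyl on an oxygen on an aromatic ring. Among the compounds with values here, the only measured step is a 1.3-fold lower number from compound 1 to compound 3 (0.11 log units; within the scatter) and it stays within the scatter, but it concerns a different group elsewhere in the molecule. It therefore gives no direct guide, and no shift beyond the scatter is expected in this assay here. The expected step is a 1.0-fold higher number from compound 2 to compound 4 (0.00 log units; within the scatter) in size. For compound 4 the estimated value is 30 ug/mL with an expected range from 16 ug/mL to 55 ug/mL around it.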

Compound 4, half-maximal inhibitory concentration: 29.7 ug/mL
Estimate against measurement, compound 4: 1.0-fold (0.00 log units) above, within the range that was stated.
By their numbers in this assay, from the lowest: compounds 4, 2, 3 and 1 (each within the scatter of the next).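

Within the data shown here, on the oxygen on an aromatic ring, propargyl in place of acetyl gives a 1.0-fold lower number from compound 2 to compound 4 (0.00 log units; within the scatter) in this assay, the first direct reading of a change at this position. In this one pair, exchanging acetyl, with its double bond and one hydrogen-bond acceptor, for propargyl, with its triple bond and no acceptor, leaves the two compounds within the scatter. No further data bear on why they read alike.

As far as these compounds go, whether a free hydroxyl or a carboxylic acid on a longer chain at this oxygen would read differently remains open.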